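This account rests on a few compounds, and the source may have more. Where it says the series, first, only, none or still open, it means among the compounds named here.

Measured compounds:

Compound 1, `O=C(/C=C/c1ccncc1-c1ccc2[nH]ccc2c1)N1CCOCC1`: 190 nM
Compound 2, `CCOC(=O)/C=C/c1ccncc1-c1ccc2[nH]ccc2c1`: 107 nM
Compound 3, `CCOC(=O)/C=C/c1ccncc1-c1ccc2cc[nH]c2c1`: 12.1 nM

All three were run in an assay on a protein complex for inhibition of CDK8/Cyclin C (Homo sapiens), with a stated time of 1 h; on this read-out lower numbers stand for stronger inhibition and higher numbers for weaker inhibition. Compound 2 and compound 3 share the same atoms joined differently; the difference between the two cores is not broken down here. In this assay compound 3 gives 12.1 nM, the lowest of the three numbers, with compound 2 at 107 nM and compound 1 at 190 nM, both gaps beyond the scatter.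

One change is seen twice among the compounds shown. From compound 2 to compound 1 it reads (morpholin-4-yl in place of ethoxy on a carbonyl carbon), and the measured step is a 1.8-fold higher number from compound 2 to compound 1 (0.25 log units; within the scatter). The same change carries compound 3 to the not yet measured compound 4, `O=C(/C=C/c1ccncc1-c1ccc2cc[nH]c2c1)N1CCOCC1`, as morpholin-4-yl in place of ethoxy on a carbonyl carbon; the place lines of the two changes agree word for word, so it is the same change on a different core.

For compound 4 the expectation rests on this one earlier step: compound 2 to compound 1 moved by a 1.8-fold higher number from compound 2 to compound 1 (0.25 log units; within the scatter), within the scatter, so a step of about the same size is expected here, and compound 4 is estimated at a 1.8-fold higher number from compound 3 to compound 4 (0.26 log units; within the scatter) against compound 3. Compound 4 is therefore estimated at 22 nM in this assay, with the range 8 nM to 60 nM; one prior instance is thin ground, so the range is kept wide.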

Compound 4, half-maximal inhibitory concentration: 43.9 nM
Estimate against measurement, compound 4: 2.0-fold (0.30 log units) below, and the stated range covers the measured number.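

In this assay, morpholin-4-yl in place of ethoxy on a carbonyl carbon gives a 3.6-fold higher number from compound 3 to compound 4 (0.56 log units; beyond the scatter), a modest step that lies beyond the scatter, whereas the same change on the other core stays within it. Set side by side, the two steps cannot be told apart: the same change on two cores in this assay, a 1.8-fold higher number (0.25 log units; within the scatter) from compound 2 to compound 1 and a 3.6-fold higher number (0.56 log units; beyond the scatter) from compound 3 to compound 4, 2.0-fold (0.31 log units) apart, within the scatter of two such steps. This gives no ground for calling the change dependent on the core, and the earlier step remains a usable guide for this pair of cores, but two cores are thin support: the data do not show that the step has a fixed size, nor that it would carry over to any further core in the series.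

The compounds shown leave open how the read-out on either core responds to other groups on the carbonyl carbon, such as the hydroxyl of a carboxylic acid, an open-chain dimethylamino group or a longer ester chain such as butoxy. They also leave open whether the ring oxygen of morpholin-4-yl has any bearing on the step, a question that piperidin-1-yl on both cores would address.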